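Three limits, and a thiophene swap still to be read

A few compounds are considered here, and "the series" means these few. Any claim that something is new, unique, unknown or untested is made for them only; others in the source may bear on it.

Compound 1 `C(=C/c1nc2ccccn2c1Sc1ccccc1)\c1ccccc1` gives > 100000 nM as a limit
Compound 2 `CSc1ccc(-c2nc3ccccn3c2Sc2ccccc2)cc1` gives > 100000 nM as a limit
Compound 3 `N#Cc1ccc(-c2nc3ccccn3c2Sc2ccccc2)cc1` gives > 100000 nM as a limit

These results come from an ADME assay on NIH3T3 cells (Mus musculus) for inhibition, read by MTT assay, with a stated time of 48 h; a higher number here means a weaker inhibitor, a lower number a stronger inhibitor. The reading for compound 3 is > 100000 nM and is a limit of the assay, not a number. Within the data shown here, the whole set sits together at one mark, the limit of > 100000 nM in this assay, at which 3 of the 3 values shown sit, and no measured compound gives a true number.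

Compound 4 `c1ccc(Sc2c(-c3ccsc3)nc3ccccn23)cc1` differs from compound 3 by one swap, thiophen-3-yl in place of 4-cyanophenyl on an aromatic carbon.

Among the measured compounds shown here, three measured steps bear on this swap: a step that the two limits leave unreadable from compound 1 to compound 2 and a step that the two limits leave unreadable from compound 1 to compound 3 and a step that the two limits leave unreadable from compound 2 to compound 3 as the closest guides. None of them has a size that can be read. With compound 3 at > 100000 nM as the starting point, no step beyond the scatter is expected in this assay.

The expected change is a number no higher from compound 3 to compound 4 (the limit leaves the size open) and no direction can be favoured. The estimate for compound 4 is 100000 nM with an expected range from 40000 nM to 250000 nM and the assay will most likely report only a limit again.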

Compound 4, half-maximal inhibitory concentration: 94100 nM
The estimate for compound 4 lay 1.1-fold (0.03 log units) above the measured number; measured number inside the range.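

Among these compounds, compound 4 is the only compound here to give a true number rather than a limit in this assay, which shows that this aromatic carbon can carry a group that keeps the reading within what the assay can report. Thiophen-3-yl at this position gives an at least 1.0-fold lower number from compound 3 to compound 4 (0.02 log units; that floor lies within the scatter), an at least 1.0-fold lower number from compound 2 to compound 4 (0.02 log units; that floor lies within the scatter) and an at least 1.0-fold lower number from compound 1 to compound 4 (0.02 log units; that floor lies within the scatter), so each step is only a floor and no real gain in strength can be claimed. The steps among the other three compounds cannot be read, and those compounds stay at one mark: the limit of > 100000 nM in this assay, at which 3 of the 4 values shown sit.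

The compounds shown leave open whether any group at this carbon gives a number clearly lower than that of compound 4. They also leave open what an amine or a carboxylic acid on the thiophene would do, or a longer chain in place of the phenylsulfanyl group.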